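The source may report more compounds than this note shows. Statements on the series, on what has been measured and on what is new or still open speak of the compounds shown alone.

Measured so far:
Compound 1, `CC(C)CC(=O)O[C@@H]1OC=C(CO[C@@H]2O[C@H](CO)[C@@H](O)[C@H](O)[C@H]2OC(=O)/C=C/c2ccc(O)cc2)[C@H]2CC[C@](O)(CO)[C@@H]12`: in a functional assay on BV-2 cells (Mus musculus) for inhibition, read by Griess assay, with stated times of 30 min and 24 h (on this read-out lower numbers stand for stronger inhibition and higher numbers for weaker inhibition), compound 1 gives 45500 nM.
Compound 2, `CC(C)CC(=O)O[C@@H]1OC=C(CO[C@@H]2O[C@H](CO)[C@@H](O)[C@H](O)[C@H]2OC(=O)/C=C\c2ccc(O)cc2)[C@H]2CC[C@](O)(CO)[C@@H]12`: in this assay compound 2 gives 900 nM.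
Compound 3, `CC(=O)OC[C@@]1(O)CC[C@@H]2C(CO[C@@H]3O[C@H](CO)[C@@H](O)[C@H](O)[C@H]3OC(=O)/C=C/c3ccc(O)cc3)=CO[C@@H](OC(=O)CC(C)C)[C@@H]21`: in this assay compound 3 gives 29800 nM.

Compound 3 stands second highest of these three numbers, close to compound 1, since a 1.5-fold lower number from compound 1 to compound 3 (0.18 log units; within the scatter); compound 2 lies far below both. Compound 4, `CC(=O)OC[C@@]1(O)CC[C@@H]2C(CO[C@@H]3O[C@H](CO)[C@@H](O)[C@H](O)[C@H]3OC(=O)/C=C\c3ccc(O)cc3)=CO[C@@H](OC(=O)CC(C)C)[C@@H]21`, has not yet been measured. It differs from compound 3 in this way: the two compounds have the same atoms and bonds and differ only in configuration as drawn: 1 of 10 stereo elements differ; a double bond is drawn E in compound 3 and Z in compound 4. The same kind of change has been measured once before: a 51-fold lower number from compound 1 to compound 2 (1.70 log units; beyond the scatter), a step that rests on (the fact that compounds 1 and 2 differ only in the configuration as drawn). That step is the one that bears here, so a large drop in the number is expected for compound 4 in this assay, namely a 50-fold lower number from compound 3 to compound 4 (1.70 log units; beyond the scatter). Compound 4 is therefore estimated at 600 nM, with a range from 200 nM to 1800 nM.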

Compound 4, half-maximal inhibitory concentration: 1200 nM
For compound 4 the middle estimate is 2.0-fold (0.30 log units) below the measured one; the measured number falls inside the stated range.
By their numbers in this assay, from the lowest: compounds 2 and 4 (each within the scatter of the next); then compounds 3 and 1 (each within the scatter of the next).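

In this assay, drawing the double bond Z rather than E again gives a large drop on a second pair of compounds, now with the acetyl present: a 25-fold lower number from compound 3 to compound 4 (1.40 log units; beyond the scatter). The acetyl in place of hydrogen, which made no difference beyond the scatter with the E double bond, also makes none with the Z double bond, a 1.3-fold higher number from compound 2 to compound 4 (0.12 log units; within the scatter), and the two acetyl steps agree: the same change on two cores in this assay, a 1.5-fold lower number (0.18 log units; within the scatter) from compound 1 to compound 3 and a 1.3-fold higher number (0.12 log units; within the scatter) from compound 2 to compound 4, 2.0-fold (0.31 log units) apart, within the scatter of two such steps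

Acetyl is the only group shown on that oxygen. On these data alone, how a longer chain, an amine or a carboxylic acid there would behave with either double bond remains open.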